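The compounds below may be only part of what the source reports. "The series", "measured", "known", "first", "only" and "open" are said of these compounds alone.

Compound 1, `Cc1ccc(CN2C(=O)S/C(=C\c3cccc(N)c3)C2=O)cc1`, carries a 3-aminophenyl group on its double-bonded chain carbon and a methyl on its benzyl ring. In a functional assay on HeLa cells (Homo sapiens) for cytotoxicity, read by cell counting, with a stated time of 4 days (on this read-out lower numbers stand for stronger inhibition and higher numbers for weaker inhibition), compound 1 gives 98000 nM. Among the compounds with values here, this is the only true number in the set; the other value is a limit. Compound 2, `Cc1ccc(CN2C(=O)S/C(=C\c3ccc(N)cc3)C2=O)cc1`, carries 4-aminophenyl in place of 3-aminophenyl. In this assay compound 2 gives > 250000 nM, which is a limit of the assay and not a number. That value is the limit of > 250000 nM in this assay, at which 1 of the 2 values shown sits. Within the data shown here, the single measured step, an at least 2.5-fold higher number from compound 1 to compound 2 (0.40 log units; beyond the scatter), therefore shows weaker inhibition when the amino group changes place.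

Compound 3, `Nc1cccc(/C=C2\SC(=O)N(Cc3ccc(Cl)cc3)C2=O)c1`, differs from compound 1 somewhere else entirely: chloro in place of methyl on an aromatic carbon. Among the measured compounds shown here, no measured step touches the benzyl ring, so the step from compound 1 to compound 2 offers no direct guide for this change. With nothing to point either way, the expected outcome is a step of no size beyond the scatter, a 1.0-fold higher number from compound 1 to compound 3 (0.01 log units; within the scatter). Compound 3 is accordingly estimated at 100000 nM, with a range from 40000 nM to 250000 nM.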

Compound 3, half-maximal inhibitory concentration: > 250000 nM
Compound 3: no number, only a limit; the forecaster's own chance of this, stated with the estimate: 20%; middle value at least 2.5-fold (0.39 log units) from the limit.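

Within the data shown here, compound 3 brings the first change on the benzyl ring, where the earlier compounds showed nothing, and it shows that this ring is not a free place in the molecule. In this assay, going from 4-methylphenyl to 4-chlorophenyl, with one heavy atom replacing one heavy atom and no change in the counted hydrogen-bond donors or acceptors, gives an at least 2.5-fold higher number from compound 1 to compound 3 (0.40 log units; beyond the scatter), which means weaker inhibition. The value of compound 3 is a limit of the assay and not a number, and both single changes shown so far, one on each side of the shared core, move away from compound 1 and end at that same limit: the limit of > 250000 nM in this assay, at which 2 of the 3 values shown sit.

Going by these compounds, it stays open whether another group in place of the methyl, such as an ethyl, a methoxy or a carboxylic acid, would hold or improve on the value of compound 1, or whether the methyl itself is what matters here. Also open, on these data alone, is whether the switch from methyl to chloro would read the same way with the 4-aminophenyl group of compound 2, which offers no true number to start from.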